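Pyridyl ketone series: methyl to methoxy on the ring

The source may report more compounds than this note shows. Statements on the series, on what has been measured and on what is new or still open speak of the compounds shown alone.

Within the data shown here, compound 2 `Cc1ccnc(-c2cnc(C(=O)CCCCCCc3ccccc3)o2)c1` gives the only number so far in an assay on isolated protein for inhibition of liver carboxylesterase 1 (Homo sapiens) (on this read-out lower numbers stand for stronger inhibition and higher numbers for weaker inhibition), where compound 2 gives 2000 nM. Compound 1 `NC(=O)c1cccc(-c2cnc(C(=O)CCCCCCc3ccccc3)o2)c1` reports in this assay > 100000 nM, which is a limit of the assay and not a number. Of the two values shown, one is therefore (the limit of > 100000 nM in this assay, at which 1 of the 2 values shown sits). The measured step of an at least 50-fold lower number from compound 1 to compound 2 (1.69 log units; beyond the scatter) is thus known only as a bound on its size. Compound 3 `COc1ccnc(-c2cnc(C(=O)CCCCCCc3ccccc3)o2)c1` differs from compound 2 in one place: methoxy in place of methyl on an aromatic carbon. Among the measured compounds shown here, the one measured step exchanges the whole aryl group for the 4-methylpyridin-2-yl group and does not touch a substituent on that group, so it gives no guide to the size or direction of this change. The expected step of no change at the digits printed from compound 2 to compound 3 (within the scatter) is therefore small, within the scatter. Compound 3 is estimated to give 2000 nM in this assay, with a range of 600 nM to 7000 nM.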

Compound 3, half-maximal inhibitory concentration: 500 nM
Estimate against measurement, compound 3: 4.0-fold (0.60 log units) above; measured number below the stated range.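

Within this assay, the position opposite the ring nitrogen responds to a substituent change alone, which the earlier exchange of the whole aryl group could not show: methoxy in place of methyl lowers the number beyond the scatter (a 4.0-fold lower number from compound 2 to compound 3 (0.60 log units; beyond the scatter)). The 4-methoxypyridin-2-yl group in place of 3-carbamoylphenyl gives a larger change (an at least 200-fold lower number from compound 1 to compound 3 (2.30 log units; beyond the scatter)), but its size is only a bound. Compound 1 sits at a limit of the assay, not at a number: the limit of > 100000 nM in this assay, at which 1 of the 3 values shown sits.

The compounds shown do not separate the effect of the oxygen from that of the extra heavy atom, which ethyl or hydroxy at this position would help to resolve. Also open, on these data alone, is whether methoxy gives a similar change with a shorter or longer chain on the ketone.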